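Working notes on a benzyl substituent change

The source may hold more compounds than are shown below. What is called first, only, known or untested is meant among the compounds shown, and "the series" means these compounds.

Within the data shown here, compound 1 `O=S(=O)(NCCCNCc1ccc(C(F)(F)F)cc1)c1cc(C(F)(F)F)cc(C(F)(F)F)c1` is measured in a functional assay on HT-29 cells (Homo sapiens) for inhibition, read by MTT assay, with a stated time of 72 h (a lower number here means a stronger inhibitor of growth, a higher number a weaker inhibitor of growth), where compound 1 gives 2900 nM, the lowest of the two numbers so far. Among the measured compounds shown here, the only other measured member, compound 2 `O=S(=O)(NCCCNCc1ccccc1)c1cc(C(F)(F)F)cc(C(F)(F)F)c1`, gives 15000 nM in this assay; the step between them is a 5.2-fold higher number from compound 1 to compound 2 (0.71 log units; beyond the scatter), hydrogen in place of trifluoromethyl on an aromatic carbon.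

Compound 3 `O=S(=O)(NCCCNCc1ccc(Cl)cc1)c1cc(C(F)(F)F)cc(C(F)(F)F)c1` has not yet been measured. Its difference from compound 1 is chloro in place of trifluoromethyl on an aromatic carbon. For the measured compounds named here, the step from compound 1 to compound 2 is the one measured change at the same aromatic carbon; it removed the trifluoromethyl entirely and the number rose modestly. Chloro in place of trifluoromethyl is a smaller change by the counts shown than hydrogen in place of trifluoromethyl, so a rise in the number that is smaller than that step is expected, and it may not exceed the scatter. For compound 3 the estimate in this assay is 5000 nM, with a range of 2000 nM to 13000 nM. The expected step is a 1.7-fold higher number from compound 1 to compound 3 (0.24 log units; within the scatter).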

Compound 3, concentration for 50% growth inhibition: 2800 nM
The estimate for compound 3 lay 1.8-fold (0.25 log units) above the measured number; low and high end bracket the measured number.
By their numbers in this assay, from the lowest: compounds 3 and 1 (each within the scatter of the next); then compound 2.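

In this assay, chloro in place of trifluoromethyl on the aromatic carbon, para to a large group, leaves the two compounds indistinguishable (the step is a 1.0-fold lower number from compound 1 to compound 3 (0.02 log units; within the scatter)), even though the entering group is smaller by the heavy-atom counts. Chloro in place of hydrogen at the same carbon gives a 5.4-fold lower number from compound 2 to compound 3 (0.73 log units; beyond the scatter), so across these three compounds the lower numbers no longer belong to trifluoromethyl alone: both compound 1 and compound 3 stand apart from the unsubstituted benzyl of compound 2, and none of the three goes against this. No measurement at hand bears on why chloro and trifluoromethyl read alike here.

The compounds shown leave open whether a fluoro, a methoxy, a nitrile, an amine or a carboxylic acid at this carbon would read like chloro and trifluoromethyl or like hydrogen. They also leave open whether the match between chloro and trifluoromethyl would hold at another carbon of the same ring, or with a longer chain in the shared core.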